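Fluoro-to-methoxy swap on the aryl ring: cytotoxicity notes

The compounds below may be only part of what the source reports. "The series", "measured", "known", "first", "only" and "open" are said of these compounds alone.

Compound 1 `C=CC1=C(C(=O)O)C(c2ccc(F)cc2)OC1`: 67400 nM
Compound 2 `C=CC1=C(C(=O)O)C(c2ccc(OC)cc2)OC1`: 44300 nM
Compound 3 `C=CC1=C(C(=O)NCc2ccc(OC)c(OC)c2)C(c2ccc(F)cc2)OC1`: > 100000 nM, a limit of the assay rather than a number

All three were run in a functional assay on HeLa cells (Homo sapiens) for cytotoxicity, read by MTT assay, with a stated time of 24 h; on this read-out lower numbers stand for stronger inhibition and higher numbers for weaker inhibition. In this assay compound 1 gives 67400 nM and compound 2 gives 44300 nM; the step of a 1.5-fold lower number from compound 1 to compound 2 (0.18 log units; within the scatter) corresponds to methoxy in place of fluoro on an aromatic carbon. Compound 3 is reported only at > 100000 nM, which is a limit of this assay and not a measured number. On that limit: the limit of > 100000 nM in this assay, at which 1 of the 3 values shown sits. The difference between the core of compound 1 and the core of compound 3 is not broken down here.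

Compound 4 `C=CC1=C(C(=O)NCc2ccc(OC)c(OC)c2)C(c2ccc(OC)cc2)OC1` has not yet been measured. It stands to compound 3 as compound 2 stands to compound 1: methoxy in place of fluoro on an aromatic carbon, the same change at the same place. Since the measured step of a 1.5-fold lower number from compound 1 to compound 2 (0.18 log units; within the scatter) lies within the scatter, the step that the limit leaves unreadable from compound 3 to compound 4 is expected to be of like size. Compound 4 is therefore estimated at 110000 nM, with an expected range from 50000 nM to 300000 nM, and a real chance that this assay again returns only a limit for compound 4.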

Compound 4, half-maximal inhibitory concentration: > 100000 nM
Compound 4: a limit, no number; the forecaster's own chance of this, stated with the estimate: 65%; the middle value lies beyond the limit too.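

Compound 4, like compound 3, returns only a limit in this assay, not a number, so the step from fluoro to methoxy between these two compounds cannot be read: the limit of > 100000 nM in this assay, at which 2 of the 4 values shown sit.

The compounds shown leave open the actual values of compound 3 and compound 4, and whether this swap changes the read-out in that pair at all.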